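A few compounds are considered here, and "the series" means these few. Any claim that something is new, unique, unknown or untested is made for them only; others in the source may bear on it.

compound 1 `CCc1ccc(NC(=O)C2CCN(C/C=C/c3ccccc3)CC2)cc1` gives 11600 nM in a functional assay on MGC-803 cells (Homo sapiens) for inhibition, read by MTT assay, with a stated time of 72 h; a higher number here means a weaker inhibitor, a lower number a stronger inhibitor
compound 2 `CCCc1ccc(NC(=O)C2CCN(C/C=C/c3ccccc3)CC2)cc1` gives 5210 nM
compound 3 `COc1cccc(NC(=O)C2CCN(C/C=C/c3ccccc3)CC2)c1` gives 37200 nM

Compound 3 holds the highest number of the three and is the weakest inhibitor among them (the steps are a 3.2-fold higher number from compound 1 to compound 3 (0.51 log units; beyond the scatter) and a 7.1-fold higher number from compound 2 to compound 3 (0.85 log units; beyond the scatter)). The change to compound 4 `COc1ccccc1NC(=O)C1CCN(C/C=C/c2ccccc2)CC1` is 2-methoxyphenyl in place of 3-methoxyphenyl on an amide-type nitrogen. Within the data shown here, no measured step makes this same exchange. The two steps just given are the closest evidence, since both also replace the group on the amide-type nitrogen, and both are modest. The remaining step shows a 2.2-fold lower number from compound 1 to compound 2 (0.35 log units; beyond the scatter) and concerns a saturated chain, so it bears less directly. A step no larger than these is therefore expected in this assay, with a slight lean to a lower number since compound 3 sits at the top of the series with 37200 nM, although the data do not settle the direction. The estimated step is a 1.4-fold lower number from compound 3 to compound 4 (0.16 log units; within the scatter) and a move the other way remains possible. For compound 4 the estimated value is 26000 nM, with an expected range from 9000 nM to 70000 nM.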

Compound 4, half-maximal inhibitory concentration: 71200 nM
Compound 4: middle estimate off by 2.7-fold (0.44 log units), on the low side, outside the stated range (above it).
By their numbers in this assay, from the lowest: compound 2; then compound 1; then compounds 3 and 4 (each within the scatter of the next).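

In this assay the exchange of 3-methoxyphenyl for 2-methoxyphenyl on the amide-type nitrogen gives a 1.9-fold higher number from compound 3 to compound 4 (0.28 log units; within the scatter) and so does not separate the two methoxyphenyl groups, which hold the same atoms joined differently. The gap to the alkylphenyl compounds holds for this second methoxyphenyl group as well: 2-methoxyphenyl in place of 4-propylphenyl gives a 14-fold higher number from compound 2 to compound 4 (1.14 log units; beyond the scatter) and is the only large step in the series, while 2-methoxyphenyl in place of 4-ethylphenyl gives a 6.1-fold higher number from compound 1 to compound 4 (0.79 log units; beyond the scatter) and stays modest, so among these four compounds both methoxyphenyl groups stand on the weak side of both alkylphenyl groups, with no compound going against this. No measurement shown here accounts for these steps.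

On these data alone, whether a longer chain such as butyl in place of the propyl of compound 2 continues the step from compound 1 to compound 2 remains open. Equally open, as far as these compounds go, is how an amine or a carboxylic acid in place of the methoxy group of compound 3 and compound 4 would read against these numbers.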